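The source may hold more compounds than are shown below. What is called first, only, known or untested is meant among the compounds shown, and "the series" means these compounds.

Measured in a functional assay on HCT-116 cells (Homo sapiens) for antiproliferative activity, read by MTT assay, with a stated time of 72 h; a lower number here means a stronger inhibitor, a higher number a weaker inhibitor:
- compound 1 `O=C(CCc1cccc2c1B(O)OC2)Nc1ccc(Br)cc1`: 46000 nM
- compound 2 `O=C(CCc1cccc2c1B(O)OC2)Nc1ccc(I)cc1`: 50000 nM
- compound 3 `C#Cc1ccc(NC(=O)CCc2cccc3c2B(O)OC3)cc1`: 45000 nM

Compound 3, at 45000 nM, lies within the scatter of compound 1 and compound 2, so no order can be drawn among the three. Compound 4 `CC(C)(C)c1ccc(NC(=O)CCc2cccc3c2B(O)OC3)cc1` is the next case: tert-butyl in place of ethynyl on an aromatic carbon. Three measured steps at this place bear on it: a 1.1-fold higher number from compound 1 to compound 2 (0.04 log units; within the scatter), a 1.0-fold lower number from compound 1 to compound 3 (0.01 log units; within the scatter) and a 1.1-fold lower number from compound 2 to compound 3 (0.05 log units; within the scatter). All three stay within the scatter, although none of these compounds carries tert-butyl. No step beyond the scatter is therefore expected in this assay. The expected step is a 1.1-fold lower number from compound 3 to compound 4 (0.05 log units; within the scatter). For compound 4 the estimate is 40000 nM, with an expected range of 18000 nM to 80000 nM.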

Compound 4, half-maximal inhibitory concentration: 19000 nM
Compound 4: the middle estimate sits 2.1-fold (0.32 log units) above what was measured; measured number inside the range.
By their numbers in this assay, from the lowest: compound 4; then compounds 3, 1 and 2 (each within the scatter of the next).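

In this assay, among the compounds shown here, this position is the first to show a step beyond the scatter: tert-butyl gives a 2.4-fold lower number from compound 3 to compound 4 (0.37 log units; beyond the scatter) and a 2.6-fold lower number from compound 2 to compound 4 (0.42 log units; beyond the scatter) and a 2.4-fold lower number from compound 1 to compound 4 (0.38 log units; beyond the scatter) in this series, while bromo, iodo and ethynyl stayed within the scatter of one another. For the compounds shown here, all three steps remain modest, so this change shifts the number without bringing it far from the level of the earlier compounds. No measured evidence accounts for the shift.

Open, as far as these compounds go, is whether the step is specific to tert-butyl or is shared by isopropyl or trimethylsilyl. Also open, from the compounds shown here alone, is how an amine or a carboxylic acid at this position would read.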